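The source may report more compounds than this note shows. Statements on the series, on what has been measured and on what is new or still open speak of the compounds shown alone.

Of the compounds shown here, two built on one shared core have been tested. Compound 1 `CC(=O)c1cc(-c2ccc(F)cc2)cc2cc(-c3ccccc3)[nH]c12` and compound 2 `COc1ccc(-c2cc3cc(-c4ccccc4)cc(C(C)=O)c3[nH]2)cc1` were both run in a functional assay on MCF7 cells (Homo sapiens) for cytotoxicity, read by MTT assay, with a stated time of 2 days, tested at 10 uM; on this read-out lower numbers stand for a stronger effect and higher numbers for a weaker effect at the one concentration tested. In this assay compound 1 gives 73.8%. In this assay compound 2 gives 64.5%, and the number for compound 1 lies within the usual scatter of that result, so the two cannot be told apart on this read-out.

The next compound, compound 3 `COc1ccc(-c2cc3cc(-c4ccc(F)cc4)cc(C(C)=O)c3[nH]2)cc1`, has not yet been measured. It differs from compound 2 in one place: fluoro in place of hydrogen on an aromatic carbon.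

Within the data shown here, no pair of measured compounds shows what such a change does here, so there is nothing to lean on beyond the two numbers above. The expected step of a number 0.5 percentage points higher from compound 2 to compound 3 (within the scatter) is therefore small, with no direction beyond the scatter. For compound 3 the estimate in this assay is 65%, with a range from 50% to 80%.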

Compound 3, a percentage reported as activity, at one concentration (the size of the read-out at that concentration, not a potency): 77.5%
For compound 3 the middle estimate is 12.5 percentage points below the measured one; measured number inside the range.
By their numbers in this assay, from the lowest: compounds 2, 1 and 3 (each within the scatter of the next, the first and the last beyond it).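

In this assay, among these compounds, the change from phenyl to 4-fluorophenyl gives a number 13 percentage points higher from compound 2 to compound 3 (beyond the scatter) and is the first step in this set that stands clear of the scatter, so with the methoxy group present, this fluoro weakens the effect at the one concentration tested. Adding the methoxy group gives a number 3.7 percentage points higher from compound 1 to compound 3 (within the scatter) and, with the fluoro present, cannot be told apart from no change. Nothing available here explains why the fluoro step shows up on this read-out.

As far as these compounds go, the comparison at this place covers only hydrogen and fluoro, so it remains open whether chloro, a methyl group, an amine or a carboxylic acid there would act in the same way. From the compounds shown here alone, it also remains open whether the fluoro step would hold without the methoxy group.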